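A few compounds are considered here, and "the series" means these few. Any claim that something is new, unique, unknown or untested is made for them only; others in the source may bear on it.

For the measured compounds named here, in a functional assay on L1210 cells (Mus musculus) for inhibition (on this read-out lower numbers stand for stronger inhibition and higher numbers for weaker inhibition), compound 1 `O=C1O/C(=C\Cn2cc(C(F)(F)F)c(=O)[nH]c2=O)C(OCc2ccccc2)=C1OCc1ccccc1` gives 2000 nM and holds the lowest of the three numbers so far. Compound 2 `O=C1O/C(=C\Cn2ccc(=O)[nH]c2=O)C(OCc2ccccc2)=C1OCc1ccccc1` gives 12900 nM and compound 3 `O=C1O/C(=C\Cn2cc(Cl)c(=O)[nH]c2=O)C(OCc2ccccc2)=C1OCc1ccccc1` gives 12200 nM and these two lie within the scatter of each other. Compound 4 `O=C1O/C(=C\Cn2cc(Br)c(=O)[nH]c2=O)C(OCc2ccccc2)=C1OCc1ccccc1` has bromo in place of trifluoromethyl on an aromatic carbon relative to compound 1. The nearest evidence is the chloro replacement with a 6.1-fold higher number from compound 1 to compound 3 (0.79 log units; beyond the scatter) and the hydrogen replacement with a 6.5-fold higher number from compound 1 to compound 2 (0.81 log units; beyond the scatter) and both lie beyond the scatter. The step of a 1.1-fold lower number from compound 2 to compound 3 (0.02 log units; within the scatter) lies within it. A similar rise is therefore expected in this assay and a 4.5-fold higher number from compound 1 to compound 4 (0.65 log units; beyond the scatter) is the estimated step. Compound 4 is estimated at 9000 nM with an expected range from 4000 nM to 16000 nM on this evidence.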

Compound 4, half-maximal inhibitory concentration: 7500 nM
Beside the measured number, compound 4's estimate is 1.2-fold (0.08 log units) above it; measured number inside the range.
By their numbers in this assay, from the lowest: compound 1; then compounds 4, 3 and 2 (each within the scatter of the next).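

In this assay bromo falls with chloro and hydrogen rather than with trifluoromethyl: the step is a 3.8-fold higher number from compound 1 to compound 4 (0.57 log units; beyond the scatter) and it stays clear of compound 1. The other two readings are a 1.6-fold lower number from compound 3 to compound 4 (0.21 log units; within the scatter) and a 1.7-fold lower number from compound 2 to compound 4 (0.24 log units; within the scatter) and neither separates the pair, so hydrogen, chloro and bromo cannot be told apart at this position and only trifluoromethyl stands alone. No available measurement accounts for what sets trifluoromethyl apart. As far as these compounds go, whether a methyl, a nitrile or an amine on this aromatic carbon would fall with compound 1 or with compounds 2, 3 and 4 remains open. So does whether the advantage of trifluoromethyl holds when the rest of the shared core changes.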